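Chlorine for Nitrile on a Benzyl Ether

A few compounds are considered here, and "the series" means these few. Any claim that something is new, unique, unknown or untested is made for them only; others in the source may bear on it.

Compound 1 `COc1ccc2c(=O)c(-c3cc(OC)c(OC)cc3OC)coc2c1` carries a plain methoxy group on the shared core. In a functional assay on U-251 cells (Homo sapiens) for antiproliferative activity, read by MTT assay, with a stated time of 24 h (on this read-out lower numbers stand for stronger inhibition and higher numbers for weaker inhibition), compound 1 gives 9400 nM. Two relatives have been measured the same way. Compound 3 `COc1cc(OC)c(-c2coc3cc(OCc4ccc(C#N)cc4)ccc3c2=O)cc1OC` gives 6180 nM in this assay, and the step of a 1.5-fold lower number from compound 1 to compound 3 (0.18 log units; within the scatter) leaves compound 1 and compound 3 within the usual scatter of each other. Compound 2 `COc1cc(OC)c(-c2coc3cc(OCC(=O)c4cccc(C(F)(F)F)c4)ccc3c2=O)cc1OC` returns only a limit of this assay, > 10000 nM. That limit of > 10000 nM in this assay, at which 1 of the 3 values shown sits, supplies no number for compound 2, so the step of an at least 1.0-fold higher number from compound 1 to compound 2 (0.02 log units; that floor lies within the scatter) is a floor rather than a size.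

Compound 4 `COc1cc(OC)c(-c2coc3cc(OCc4ccc(Cl)cc4)ccc3c2=O)cc1OC` is not yet measured. It differs from compound 1 by 4-chlorophenyl in place of hydrogen on a saturated chain carbon bound to an oxygen on an aromatic ring. The closest measured comparison is a 1.5-fold lower number from compound 1 to compound 3 (0.18 log units; within the scatter), where 4-cyanophenyl entered at the same place and the number stayed within the scatter. A 4-chlorophenyl at that place is therefore expected to move the number little, if at all, beyond the scatter, and compound 4 is expected to give 7000 nM in this assay, with a likely range from 3000 nM to 15000 nM. This estimate amounts to an expected step of a 1.3-fold lower number from compound 1 to compound 4 (0.13 log units; within the scatter), which would sit within the scatter.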

Compound 4, half-maximal inhibitory concentration: 470 nM
For compound 4 the middle estimate is 15-fold (1.17 log units) above the measured one, and the stated range ends above it.
By their numbers in this assay, from the lowest: compound 4; then compounds 3 and 1 (each within the scatter of the next). At a limit, above all of these: compound 2.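

In this assay, the size of the group at the end of the benzyl ether proves less telling than its identity: with everything else kept, chloro in place of cyano on an aromatic carbon gives a 13-fold lower number from compound 3 to compound 4 (1.12 log units; beyond the scatter). Measured against the plain methoxy group, the (4-chlorobenzyl)oxy group gives a 20-fold lower number from compound 1 to compound 4 (1.30 log units; beyond the scatter), while the 4-cyanophenyl group had stayed within the scatter, so among compounds 1, 3 and 4, putting an aromatic ring on this chain carbon does not by itself produce the large drop, and the substituent on that ring matters. Compound 2 remains at a limit of the assay, so an at least 21-fold lower number from compound 2 to compound 4 (1.32 log units; beyond the scatter) is a floor, though one already beyond the scatter: the limit of > 10000 nM in this assay, at which 1 of the 4 values shown sits.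

The compounds shown leave open whether this large step belongs to chloro alone or would also appear with bromo, fluoro or methyl in its place. They also say nothing about an amine or a carboxylic acid on that ring, or about why chloro and nitrile end so far apart.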